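Shortening the oxolane link in the nitro-aniline side chain

The source may report more compounds than this note shows. Statements on the series, on what has been measured and on what is new or still open speak of the compounds shown alone.

The series rests on the core of compound 1, `CCN(CC)CCCNc1ccc(S(=O)(=O)NC(=O)c2ccc(N3CCN(CC4=C(c5ccc(C(F)(F)F)cc5)CC(C)(C)CC4)CC3)cc2Oc2cnc3[nH]ccc3c2)cc1[N+](=O)[O-]`, which in an assay on isolated protein for displacement of a labelled ligand from Apoptosis regulator Bcl-2 (Homo sapiens), with a stated time of 15 min (on this read-out higher numbers stand for weaker inhibition and lower numbers for stronger inhibition), gives 0.3 nM. Among the measured compounds shown here, compound 2, `CC1(C)CCC(CN2CCN(c3ccc(C(=O)NS(=O)(=O)c4ccc(NCC5CCOC5)c([N+](=O)[O-])c4)c(Oc4cnc5[nH]ccc5c4)c3)CC2)=C(c2ccc(C(F)(F)F)cc2)C1`, gives 4.7 nM in this assay, the highest of the two numbers measured so far; the single measured step, a 16-fold higher number from compound 1 to compound 2 (1.19 log units; beyond the scatter), leads to it and is large. Compound 3, `CC1(C)CCC(CN2CCN(c3ccc(C(=O)NS(=O)(=O)c4ccc(NC5CCOC5)c([N+](=O)[O-])c4)c(Oc4cnc5[nH]ccc5c4)c3)CC2)=C(c2ccc(C(F)(F)F)cc2)C1`, is not yet measured. Its difference from compound 2 is oxolan-3-yl in place of (oxolan-3-yl)methyl on a nitrogen on an aromatic ring, the methylene link of the side chain dropping out while the oxolane ring and the ring nitrogen remain. For the measured compounds named here, no measured step touches exactly this change; the step from compound 1 to compound 2 exchanged the whole group on that nitrogen, so it shows only that this region of the molecule responds strongly to substitution. For a trimming as small as this, the expected step, a 1.5-fold higher number from compound 2 to compound 3 (0.17 log units; within the scatter), is modest and may well lie within the scatter, with a slight lean towards a higher number. Compound 3 is therefore estimated at 7 nM in this assay, with a range from 2 nM to 25 nM.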

Compound 3, half-maximal inhibitory concentration: 1.9 nM
Compound 3: middle estimate off by 3.7-fold (0.57 log units), on the high side; measured number below the stated range.
By their numbers in this assay, from the lowest: compound 1; then compound 3; then compound 2.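

In this assay, the methylene link in the side chain turns out to matter in its own right: dropping it gives a 2.5-fold lower number from compound 2 to compound 3 (0.39 log units; beyond the scatter), so at this nitrogen on an aromatic ring, oxolan-3-yl gives a lower number than (oxolan-3-yl)methyl and the trimming does not add to the loss seen earlier. Compound 1 still keeps the lowest number of the three, but with the directly attached ring the gap to the 3-(diethylamino)propyl side chain is a 6.3-fold higher number from compound 1 to compound 3 (0.80 log units; beyond the scatter), against a 16-fold higher number from compound 1 to compound 2 (1.19 log units; beyond the scatter) for the linked ring, so part of that earlier loss depends on the link and not only on the exchange of the whole group. Nothing at hand explains why the shorter attachment gives the lower number.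

The compounds shown leave open whether the gain from direct attachment is particular to oxolan-3-yl or also holds for a larger ring such as oxan-4-yl. They also leave open whether an amine carried on the directly attached ring, as in pyrrolidin-3-yl or 1-methylpiperidin-4-yl, would close the remaining gap to compound 1.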